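Methyl for Methoxy on the Aryl Ketone of an Aminothiophene

The source may report more compounds than this note shows. Statements on the series, on what has been measured and on what is new or still open speak of the compounds shown alone.

Measured so far:
- compound 1, `COC(=O)c1c(Nc2ccccc2)sc(C(=O)c2ccc(C)cc2)c1C`, gives 8.16%
- compound 2, `COc1ccc(C(=O)c2sc(Nc3ccccc3)c(C(=O)O)c2C)cc1`, gives 52.6%

Both compounds were tested in a functional assay, with a stated time of 150 min, tested at 25 ug/mL; a higher number here means a stronger effect of the compound at the concentration tested, a lower number a weaker effect. Compound 2 stands highest of the two numbers; compound 1 is the nearest, and its value lies well below that of compound 2, a gap beyond the usual scatter of this kind of measurement. Compound 1, however, differs from compound 2 in more than one place, so nothing in these two numbers can be tied to a single group.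

Compound 3, `Cc1ccc(C(=O)c2sc(Nc3ccccc3)c(C(=O)O)c2C)cc1`, has not yet been measured. It differs from compound 2 in one place only: methyl in place of methoxy on an aromatic carbon.

Going by the values given here, no step between two measured compounds that differ in exactly this way is available, so the expectation rests on the pair above alone. Because compound 1, which carries a methyl on the same ring, gives 8.16%, a step downward is expected, of modest size and possibly within the scatter: a number 14.6 percentage points lower from compound 2 to compound 3 (beyond the scatter). Compound 3 is therefore estimated to give 38%, with a likely range from 15% to 60%.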

Compound 3, a percentage reported as activity, at one concentration (the size of the read-out at that concentration, not a potency): 4.35%
Estimate against measurement, compound 3: 33.7 percentage points above, and the stated range ends above it.
By their numbers in this assay, from the lowest: compounds 3 and 1 (each within the scatter of the next); then compound 2.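

In this assay the step of a number 48.3 percentage points lower from compound 2 to compound 3 (beyond the scatter) is large and comes from a single change, 4-methoxyphenyl to 4-methylphenyl, so the high reading of compound 2 depends on the methoxy group at this place on the ring, para to a large group, when the acid is present. The comparison of compound 1 with compound 2 could not show this, as those two differ in more than one place. With the 4-methylphenyl group kept, the step of a number 3.8 percentage points lower from compound 1 to compound 3 (within the scatter) shows that replacing the methyl of the ester with hydrogen makes no difference that can be told from the scatter, and nothing measured here explains why the methoxy group matters so much.

Going by these compounds, it remains open whether the same swap between the ester and the acid would also leave the reading unchanged with the methoxy group on the ring. On these data alone, it is also open whether an ethoxy group, a hydroxyl group or a chlorine atom at this place would behave like methoxy or like methyl.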